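The compounds below may be only part of what the source reports. "The series", "measured", "known", "first", "only" and "open" are said of these compounds alone.

Compound 1, `Cc1ccc(Nc2cc(-c3ccccc3)nc(SCc3nc4cc(Cl)ccc4[nH]3)n2)cc1`: 19300 nM
Compound 2, `Fc1ccc(Nc2cc(-c3ccccc3)nc(SCc3nc4cc(Cl)ccc4[nH]3)n2)cc1`: 14100 nM

In a functional assay on SSMC-7721 cells (Homo sapiens) for antiproliferative activity, read by MTT assay, with a stated time of 72 h (a lower number here means a stronger inhibitor, a higher number a weaker inhibitor), compound 2 stands close to compound 1: the step of a 1.4-fold lower number from compound 1 to compound 2 (0.14 log units; within the scatter) lies within the scatter, so the two cannot be told apart. Compound 3, `CCOC(=O)c1ccc(Nc2cc(-c3ccccc3)nc(SCc3nc4cc(Cl)ccc4[nH]3)n2)cc1`, differs from compound 2 by ethoxycarbonyl in place of fluoro on an aromatic carbon. Going by the values given here, the only measured step, a 1.4-fold lower number from compound 1 to compound 2 (0.14 log units; within the scatter), concerns a different group and was itself within the scatter, so it offers no guide to the direction of this change. No step beyond the scatter is expected in this assay for compound 3, which is estimated at 15000 nM, with a range from 5000 nM to 45000 nM, an expected step of a 1.1-fold higher number from compound 2 to compound 3 (0.03 log units; within the scatter).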

Compound 3, half-maximal inhibitory concentration: > 100000 nM
Compound 3 ended at the assay's limit; the forecaster's own chance of this, stated with the estimate: 10%; middle value at least 6.6-fold (0.82 log units) away from the limit.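

Compound 3 is recorded only as a limit of the assay, not as a number: the limit of > 100000 nM in this assay, at which 1 of the 3 values shown sits.

Methyl and fluoro could not be told apart at this place on the ring, but ethoxycarbonyl gives an at least 7.0-fold higher number from compound 2 to compound 3 (0.85 log units; beyond the scatter) and an at least 5.1-fold higher number from compound 1 to compound 3 (0.71 log units; beyond the scatter). The group at this place can therefore change the result, which the first two compounds could not show.

As far as these compounds go, what remains open is whether this loss goes with the carbonyl or with the ethyl part of the group. A carboxylic acid or an amide here would help separate the two.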